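The source may hold more compounds than are shown below. What is called first, only, known or untested is meant among the compounds shown, and "the series" means these compounds.

Compound 1 `CSc1nn(-c2ccccc2)c2nc(Nc3ccccc3)n(-c3ccccc3)c(=O)c12` and compound 2 `O=c1c2c(Nc3ccccc3)nn(-c3ccccc3)c2nc(Nc2ccccc2)n1-c1ccccc1` share one core. Going by the values given here, in a functional assay on the whole organism (strain Wistar albino) for inhibition, with Rattus norvegicus as the target, read by paw edema, with a stated time of 1 h, at a dose of 25 mg/kg by the oral route (on this read-out higher numbers stand for more inhibition at the one dose given (going by the name of the read-out) and lower numbers for less inhibition), compound 1 gives 46.1% and compound 2 gives 48.1%; the one measured step, a number 2 percentage points higher from compound 1 to compound 2 (within the scatter), is the anilino in place of methylsulfanyl change. Compound 2 stands with the higher of the two numbers, but within the scatter of compound 1. Compound 3 `NS(=O)(=O)c1ccc(-n2nc(Nc3ccccc3)c3c(=O)n(-c4ccccc4)c(Nc4ccccc4)nc32)cc1` differs from compound 2 by sulfamoyl in place of hydrogen on an aromatic carbon, read one bond further out as phenyl to 4-sulfamoylphenyl. Among the compounds with values here, no measured step touches this change, so nothing beyond the scatter is expected. The expected step is a number 0.1 percentage points lower from compound 2 to compound 3 (within the scatter). For compound 3 the estimate is 48%, between 30% and 65%.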

Compound 3, a percentage reported as inhibition, in the whole organism at one dose (the size of the read-out at that dose, not a potency): 60.2%
Beside the measured number, compound 3's estimate is 12.2 percentage points below it; the measured number falls inside the stated range.
By their numbers in this assay, from the lowest: compounds 1 and 2 (each within the scatter of the next); then compound 3.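

In this assay, phenyl to 4-sulfamoylphenyl gives a number 12.1 percentage points higher from compound 2 to compound 3 (beyond the scatter), so this place on the ring, para to a large group, takes sulfamoyl with a modest gain. Going by these compounds alone, this is the first change to pass the scatter, unlike anilino in place of methylsulfanyl, and it shows that inhibition at this dose can move with substitution on this phenyl. Nothing available accounts for the step.

From the compounds shown here alone, a carboxylic acid or a methylsulfonyl group at the same place remains open, so the step cannot yet be assigned to sulfamoyl specifically. Also open, going by these compounds, is whether sulfamoyl gives a similar step with methylsulfanyl in place of anilino.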